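Ethoxy to propoxy on the shared core

The source may hold more compounds than are shown below. What is called first, only, known or untested is meant among the compounds shown, and "the series" means these compounds.

Compound 1 `COc1cc(/C=C\c2ccc(C(C)(C)C)cc2)cc(OC)c1OC`: 2.1 uM
Compound 2 `COc1cc(/C=C\c2ccc(C(C)C)cc2)cc(OC)c1OC`: 4.7 uM
Compound 3 `CCOc1ccc(/C=C\c2cc(OC)c(OC)c(OC)c2)cc1`: 2.5 uM

All three values come from a functional assay on SK-MEL-5 cells (Homo sapiens) for cytotoxicity; on this read-out lower numbers stand for an effect already at smaller amounts and higher numbers for an effect only at larger amounts of compound. Compound 3 stands within the scatter of both other compounds, with a 1.2-fold higher number from compound 1 to compound 3 (0.08 log units; within the scatter) and a 1.9-fold lower number from compound 2 to compound 3 (0.27 log units; within the scatter).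

The open question is compound 4 `CCCOc1ccc(/C=C\c2cc(OC)c(OC)c(OC)c2)cc1`, which carries propoxy where compound 3 carries ethoxy: methyl in place of hydrogen on a saturated chain carbon, two bonds along the chain from an oxygen on an aromatic ring. Among the measured compounds shown here, no measured step covers this exact change. For the measured compounds named here, the closest in kind is a 2.2-fold higher number from compound 1 to compound 2 (0.35 log units; beyond the scatter), the only step beyond the scatter and a modest one. It also concerns a methyl on a saturated chain carbon, but that carbon is bound to an aromatic carbon, so it transfers only loosely. The two exchanges of ethoxy for tert-butyl or isopropyl both stayed within the scatter.

On this evidence, the single added methyl is expected to produce no step beyond the scatter in this assay, and the data do not settle a direction. The estimated change is a 1.1-fold higher number from compound 3 to compound 4 (0.05 log units; within the scatter). For compound 4 the expected value is 2.8 uM, with an estimated range of 1.2 uM to 6 uM.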

Compound 4, concentration for half-maximal effect: 1.4 uM
Compound 4: the middle estimate sits 2.0-fold (0.30 log units) above what was measured; the range from low to high includes it.
By their numbers in this assay, from the lowest: compounds 4, 1, 3 and 2 (each within the scatter of the next, the first and the last beyond it).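

Notes on the propoxy result: in this assay, going from ethoxy to propoxy on the shared core gives a 1.8-fold lower number from compound 3 to compound 4 (0.25 log units; within the scatter), so this position takes the extra methyl without a step that can be told apart from the scatter. Propoxy also stays within the scatter of tert-butyl, with a 1.5-fold lower number from compound 1 to compound 4 (0.18 log units; within the scatter), whereas against isopropyl it gives the one new step beyond the scatter, a 3.4-fold lower number from compound 2 to compound 4 (0.53 log units; beyond the scatter). The exchange of methyl and hydrogen on a saturated chain carbon can now be read at two different places, and the two readings agree in direction and do not differ beyond the scatter: the same change on two cores in this assay, a 2.2-fold higher number (0.35 log units; beyond the scatter) from compound 1 to compound 2 and a 1.8-fold higher number (0.25 log units; within the scatter) from compound 4 to compound 3, 1.3-fold (0.10 log units) apart, within the scatter of two such steps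

The compounds shown leave open whether the small step seen on going from ethoxy to propoxy is real or only scatter, and whether it would continue with a longer chain such as butoxy or pentoxy. They also leave open how this position responds to a branched isopropoxy group, or to an amine or a carboxylic acid at the end of the chain, since every group shown here is a plain alkyl or alkoxy group.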